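Working notes on a small cytotoxicity series

The source may hold more compounds than are shown below. What is called first, only, known or untested is meant among the compounds shown, and "the series" means these compounds.

Measured so far in a functional assay on UACC-62 cells (Homo sapiens) for cytotoxicity, read by sulforhodamine B assay, with a stated time of 48 h; a lower number here means a stronger inhibitor of growth, a higher number a weaker inhibitor of growth:
compound 1 `ClCc1cccc(Cn2cnc3c(Cl)ncnc32)c1` gives 3380 nM;
compound 2 `ClCc1ccc(Cn2cnc3nc(Cl)nc(Cl)c32)cc1` gives 3160 nM;
compound 3 `ClCc1cccc(Cn2cnc3c(Cl)nc(Cl)nc32)c1` gives 3460 nM.

All three numbers lie within the usual scatter of one another, so no order among them is drawn. Compound 3 and compound 1 differ in one place, (hydrogen in place of chloro on an aromatic carbon), and the step of a 1.0-fold lower number from compound 3 to compound 1 (0.01 log units; within the scatter) shows that the number is left essentially where it was. The difference between the cores of compound 2 and compound 3 is not broken down here. Compound 4 `ClCc1ccc(Cn2cnc3ncnc(Cl)c32)cc1` is not yet measured; it stands to compound 2 as compound 1 stands to compound 3, the change being (hydrogen in place of chloro on an aromatic carbon), the same change at the same place. In this assay the step from compound 2 to compound 4 is expected to be a 1.0-fold higher number from compound 2 to compound 4 (0.01 log units; within the scatter), resting on a 1.0-fold lower number from compound 3 to compound 1 (0.01 log units; within the scatter) being within the scatter. Compound 4 is therefore estimated at 3200 nM, expected to fall between 1600 nM and 6400 nM.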

Compound 4, concentration for total growth inhibition: 12000 nM
Compound 4: middle estimate off by 3.8-fold (0.57 log units), on the low side; measured number outside the range, above it.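

In this assay, hydrogen in place of chloro on an aromatic carbon gives a 3.8-fold higher number from compound 2 to compound 4 (0.58 log units; beyond the scatter), so the change moves the number on this core. Set beside the earlier step, the change does not carry over unaltered from one core to the other: the same change on two cores in this assay, a 1.0-fold lower number (0.01 log units; within the scatter) from compound 3 to compound 1 and a 3.8-fold higher number (0.58 log units; beyond the scatter) from compound 2 to compound 4, 3.9-fold (0.59 log units) apart, beyond the scatter of two such steps. With a single pair on each core, this does not show which feature of the cores sets the two steps apart, nor what the change would do on any further core.

Left open is how an amine or a methoxy group at this place would compare with chloro and hydrogen on either core. Also open, from the compounds shown here alone, is whether any such group would show the same difference between the two cores.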